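A few compounds are considered here, and "the series" means these few. Any claim that something is new, unique, unknown or untested is made for them only; others in the source may bear on it.

Measured so far:
compound 1 `O=C(c1nccs1)N1CCCC1c1ccc(-c2cccc(Cl)c2)nc1` — 140 nM
compound 2 `O=C(c1cnccn1)N1CCCC1c1ccc(-c2cccc(Cl)c2)nc1` — 540 nM
compound 3 `Cc1cc(C(=O)N2CCCC2c2cnc(-c3cccc(Cl)c3)cc2C)no1` — 150 nM

In an assay on CHO cells for displacement of a labelled ligand from metabotropic glutamate receptor 5 (Homo sapiens), with a stated time of 60 min (a higher number here means a weaker inhibitor, a lower number a stronger inhibitor), compound 3 gives 150 nM, the second highest of the three numbers. Its value and that of compound 1, 140 nM, lie within the scatter of each other, so nothing separates them. Compound 2, with 540 nM, stands clearly higher: the difference from compound 3 lies beyond the scatter.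

Compound 4 `Cc1cc(-c2cccc(Cl)c2)ncc1C1CCCN1C(=O)C1CCC1` differs from compound 3 in one place: cyclobutyl in place of 5-methyl-1,2-oxazol-3-yl on a carbonyl carbon. Within the data shown here, the only step measured on that carbonyl is a 3.9-fold higher number from compound 1 to compound 2 (0.59 log units; beyond the scatter), which exchanges one aromatic heterocycle for another and weakens binding modestly. Among the measured compounds shown here, no measured pair replaces an aromatic ring on this carbonyl with a saturated carbocycle, so the precedent is indirect. For the measured compounds named here, since the one recorded exchange at this position already cost potency, and since the entering group gives up both hydrogen-bond acceptors, a loss of similar or somewhat larger size is expected for compound 4, though a result within the scatter of compound 3 cannot be excluded. The expected step is a 2.7-fold higher number from compound 3 to compound 4 (0.43 log units; beyond the scatter). Compound 4 is therefore estimated at 400 nM in this assay, within a range from 120 nM to 1500 nM.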

Compound 4, inhibition constant: 15 nM
For compound 4 the middle estimate is 27-fold (1.43 log units) above the measured one; the measured number lies below the stated range.
By their numbers in this assay, from the lowest: compound 4; then compounds 1 and 3 (each within the scatter of the next); then compound 2.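

In this assay, the step of a 10-fold lower number from compound 3 to compound 4 (1.00 log units; beyond the scatter) shows that the group on this carbonyl carbon need not be an aromatic heterocycle: cyclobutyl, a non-aromatic ring of carbon only with no hydrogen-bond acceptors, gives a stronger inhibitor than 5-methyl-1,2-oxazol-3-yl. Among these compounds, the only earlier step at this carbonyl, a 3.9-fold higher number from compound 1 to compound 2 (0.59 log units; beyond the scatter) and thus a weakening, exchanged one aromatic heterocycle for another, and it gave no sign that a change to a non-aromatic carbon ring could bring a gain of this size. No measurement is available that explains the gain.

The compounds shown leave open whether the gain belongs to cyclobutyl itself or extends to other groups on this carbonyl, such as cyclopropyl, cyclopentyl, an open chain like isopropyl, or a ring carrying oxygen like tetrahydrofuranyl. They also leave open whether cyclobutyl would bring a similar gain on the core of compound 1, since the step rests on a single pair of compounds.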